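Chlorophenyl for Benzothiophenyl: Estimating Compound 4

A few compounds are considered here, and "the series" means these few. Any claim that something is new, unique, unknown or untested is made for them only; others in the source may bear on it.

Compound 1 `Cc1ccc(-n2nc(-c3ccccc3)nc2CNc2ccc(C(=O)NO)cc2)cc1` gives 310 nM in an assay on Sf9 cells for inhibition of protein deacetylase HDAC6 (Homo sapiens), read by fluorescence, with a stated time of 40 min; a higher number here means a weaker inhibitor, a lower number a stronger inhibitor.
Compound 2 `O=C(NO)c1ccc(NCc2nc(-c3ccccc3)nn2-c2cccc(Cl)c2)cc1` gives 678 nM in this assay.
Compound 3 `O=C(NO)c1ccc(NCc2nc(-c3cc4ccccc4s3)nn2-c2ccccc2)cc1` gives 324 nM in this assay.

Compound 3 holds the second highest of the three numbers; its number and that of compound 1 lie within the scatter, while compound 2 sits beyond it, higher. Going by the values given here, the only single-place step measured, a 2.2-fold higher number from compound 1 to compound 2 (0.34 log units; beyond the scatter), concerns the group on the aromatic nitrogen and not the aromatic carbon changed here. Compound 4 `O=C(NO)c1ccc(NCc2nc(-c3ccccc3Cl)nn2-c2ccccc2)cc1` differs from compound 3 by 2-chlorophenyl in place of 1-benzothiophen-2-yl on an aromatic carbon. Among the compounds with values here, no measured step bears on that position, so no direction can be read from the data. Compound 4 is therefore expected to give roughly 400 nM in this assay, between 150 nM and 1100 nM, a step of a 1.2-fold higher number from compound 3 to compound 4 (0.09 log units; within the scatter) that is estimated to stay within the scatter.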

Compound 4, half-maximal inhibitory concentration: 185 nM
Compound 4: middle estimate off by 2.2-fold (0.33 log units), on the high side, within the range that was stated.
By their numbers in this assay, from the lowest: compounds 4, 1 and 3 (each within the scatter of the next); then compound 2.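

Going by these compounds alone, the first measured step at this aromatic carbon, on the five-membered aromatic ring with 3 nitrogen, gives a 1.8-fold lower number from compound 3 to compound 4 (0.24 log units; within the scatter) in this assay. This position therefore accepts both 1-benzothiophen-2-yl, with its two aromatic rings, and the single ring of 2-chlorophenyl, and this assay does not separate the two groups. No evidence is available to explain this step. On these data alone, what an amine or a carboxylic acid on this carbon would do remains open. So does the contribution of the chlorine in 2-chlorophenyl, which no pair among these compounds isolates.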